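Removing a ring hydroxy from a weakly active terpenoid quinol

The source may report more compounds than this note shows. Statements on the series, on what has been measured and on what is new or still open speak of the compounds shown alone.

Measured compounds:
compound 1 `COC1=C(O)[C@H](O)[C@H](C/C=C(\C)CC/C=C(\C)C[C@H](O)/C=C(\C)CO)[C@@H](C)C1=O` — > 30000 nM
compound 2 `COC1=C(OC)[C@H](OC(C)=O)[C@H](C/C=C(\C)CC/C=C(\C)C[C@H](O)/C=C(\C)CO)[C@@H](C)C1=O` — 29000 nM

The two measured compounds were tested in a functional assay on A549 cells (Homo sapiens) for inhibition, read by sulforhodamine B assay, with a stated time of 48 h; on this read-out lower numbers stand for stronger inhibition of growth and higher numbers for weaker inhibition of growth. Compound 1 `COC1=C(O)[C@H](O)[C@H](C/C=C(\C)CC/C=C(\C)C[C@H](O)/C=C(\C)CO)[C@@H](C)C1=O` gives only a limit in this assay, > 30000 nM, so its true concentration is not known beyond that bound (the limit of > 30000 nM in this assay, at which 1 of the 2 values shown sits). Compound 2 `COC1=C(OC)[C@H](OC(C)=O)[C@H](C/C=C(\C)CC/C=C(\C)C[C@H](O)/C=C(\C)CO)[C@@H](C)C1=O` differs from compound 1 in several places. In this assay compound 2 gives 29000 nM; the two values together show that both compounds are weak inhibitors of growth on these cells.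

Compound 3 `COC1=C[C@H](O)[C@H](C/C=C(\C)CC/C=C(\C)C[C@H](O)/C=C(\C)CO)[C@@H](C)C1=O` is the unmeasured compound. It differs from compound 1 by hydrogen in place of hydroxy on a double-bonded ring carbon, on a double-bonded ring carbon of the shared core. Among the compounds with values here, no step between measured compounds bears on such a change, so there is no basis for expecting a large shift in this assay in either direction; the step from compound 1 is expected to stay within the usual scatter, a number no higher from compound 1 to compound 3 (the limit leaves the size open). Compound 3 is therefore estimated at 30000 nM in this assay, within a range of 10000 nM to 90000 nM, with a real chance that only a limit is reported.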

Compound 3, concentration for 50% growth inhibition: > 30000 nM
Compound 3 was reported as a limit; the forecaster's own chance of this, stated with the estimate: 50%; the middle value lies on the limit itself.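

Compound 1 and compound 3 both stand at a limit rather than a number, so no step between them can be read: the limit of > 30000 nM in this assay, at which 2 of the 3 values shown sit.

The compounds shown leave open whether hydrogen in place of hydroxy on a double-bonded ring carbon changes growth inhibition at all, and how far the true concentrations of compound 1 and compound 3 lie from that limit.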